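The compounds below may be only part of what the source reports. "The series", "measured", "known", "first", "only" and "open" are said of these compounds alone.

Compound 1 `COc1cc(Cl)cc(-c2nn(-c3cccc(NC(=O)Nc4cccc(C(F)(F)F)c4)c3)cc2-c2ccncc2)c1`: 99%
Compound 2 `COc1cc(Cl)cc(-c2nn(-c3cccc(NC(=O)c4cccc(C(F)(F)F)c4)c3)cc2-c2ccncc2)c1`: 101%

Compound 1 `COc1cc(Cl)cc(-c2nn(-c3cccc(NC(=O)Nc4cccc(C(F)(F)F)c4)c3)cc2-c2ccncc2)c1` and compound 2 `COc1cc(Cl)cc(-c2nn(-c3cccc(NC(=O)c4cccc(C(F)(F)F)c4)c3)cc2-c2ccncc2)c1` were both measured in a functional assay on RPMI-8226 cells (Homo sapiens) for inhibition, read by sulforhodamine B assay, with a stated time of 48 h, tested at 0.01 uM; on this read-out lower numbers stand for a stronger effect and higher numbers for a weaker effect at the one concentration tested. Compound 1 gives 99%, and compound 2 gives 101%. Among the measured compounds shown here, the only measured step, a number 2 percentage points higher from compound 1 to compound 2 (within the scatter), swaps a urea for an amide and leaves the read-out where it was. Compound 1 therefore holds the lowest of the two numbers, yet its nearest neighbour, compound 2, sits within the scatter of it, so no order between them can be claimed.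

The unmeasured compound 3 `COc1cc(Cl)cc(-c2nn(-c3cccc(NC(=O)Nc4cc(C(F)(F)F)cc(C(F)(F)F)c4)c3)cc2-c2ccncc2)c1` keeps the urea of compound 1 and differs from it by trifluoromethyl in place of hydrogen on an aromatic carbon. For the measured compounds named here, no measured step in this set touches that ring, so the expectation leans on the one step that exists, which was flat, and on both measured numbers sitting near the top of the scale. In this assay compound 3 is expected to give 98%, a step of a number 1 percentage points lower from compound 1 to compound 3 (within the scatter) that stays within the scatter, with an estimated range from 86% to 108%.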

Compound 3, a percentage reported as activity, at one concentration (the size of the read-out at that concentration, not a potency): 93%
For compound 3 the middle estimate is 5 percentage points above the measured one, and the stated range covers the measured number.
By their numbers in this assay, from the lowest: compounds 3, 1 and 2 (each within the scatter of the next).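

In this assay, the earlier pair had tested only the link, a urea against an amide, and had left the aromatic ring carrying the trifluoromethyl group untouched. Among the compounds shown here, compound 3 is the first to probe that ring: a second trifluoromethyl group on an aromatic carbon, meta to the first trifluoromethyl group and meta to a large group, gives a number 6 percentage points lower from compound 1 to compound 3 (within the scatter) and so adds 4 heavy atoms without a difference that can be told from the scatter. At this single low concentration, neither the link nor this ring position has yet separated any compounds, so the read-out shows that the position accepts the larger group but says nothing about potency. No measurement is available that could account for these numbers.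

On these data alone, it remains open whether a different group at this aromatic carbon, such as an amine, a carboxylic acid or a methoxy group, would move the read-out beyond the scatter. Also open, as far as these compounds go, is how the second trifluoromethyl group would behave on the amide of compound 2, and whether these compounds would separate at higher concentrations.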